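The source may hold more compounds than are shown below. What is called first, only, known or untested is meant among the compounds shown, and "the series" means these compounds.

Compound 1 `Oc1cccc(-c2cc(-c3ccco3)cc(-c3cccc(O)c3)n2)c1` is one of two compounds tested in a functional assay on HeLa cells (Homo sapiens) for cytotoxicity, read by CCK-8 assay (a higher number here means a weaker inhibitor, a lower number a stronger inhibitor), where compound 1 gives 5990 nM. Within the data shown here, its companion, compound 2 `Oc1ccc(-c2cc(-c3ccco3)cc(-c3cccc(O)c3)n2)cc1`, gives 5170 nM in this assay; the only measured step, a 1.2-fold lower number from compound 1 to compound 2 (0.06 log units; within the scatter), leaves the pair indistinguishable. Compound 3 `Oc1cccc(-c2cc(-c3cccnc3)cc(-c3cccc(O)c3)n2)c1` differs from compound 1 by pyridin-3-yl in place of furan-2-yl on an aromatic carbon. Among the measured compounds shown here, no measured step touches a change of this kind, as the step between compound 1 and compound 2 concerns only the hydroxyphenyl group, so nothing beyond the scatter is expected in this assay. Compound 3 is therefore estimated at 6000 nM, between 2000 nM and 18000 nM, a step of a 1.0-fold higher number from compound 1 to compound 3 (0.00 log units; within the scatter) expected to stay within the scatter.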

Compound 3, half-maximal inhibitory concentration: > 50000 nM
Compound 3 ended at the assay's limit (the forecaster's own chance of this, stated with the estimate: 10%); middle value at least 8.3-fold (0.92 log units) away from the limit.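

Unlike the hydroxyphenyl change, which stayed within the scatter, the group opposite the ring nitrogen matters in this assay: pyridin-3-yl in place of furan-2-yl gives an at least 8.3-fold higher number from compound 1 to compound 3 (0.92 log units; beyond the scatter). So this position does not tolerate every aromatic ring with one hetero atom. The value of compound 3 is a limit, not a number: the limit of > 50000 nM in this assay, at which 1 of the 3 values shown sits.

From the compounds shown here alone, how large the step really is stays open, as does whether it follows from the five-membered ring being replaced by a six-membered one or from the ring nitrogen itself. Thiophen-2-yl or plain phenyl at this position would help to separate these two readings.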